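The source may hold more compounds than are shown below. What is called first, only, known or untested is meant among the compounds shown, and "the series" means these compounds.

Within the data shown here, in a functional assay on L1210 cells (Mus musculus), read by MTT assay (a lower number here means a stronger inhibitor, a higher number a weaker inhibitor), compound 2 `CC[C@@]1(O)[C@@H](CO)O[C@@H](n2ccc(N)nc2=O)[C@@H]1O` is the one compound of the three for which a number is reported, at 269000 nM. Compound 1 `C#CC[C@@]1(O)[C@@H](CO)O[C@@H](n2ccc(=O)[nH]c2=O)[C@@H]1O` reaches only a limit of the assay, > 350000 nM. Compound 3 `C#C[C@@H]1[C@@H](O)[C@H](n2ccc(N)nc2=O)O[C@@H]1CO` likewise reaches only a limit, > 350000 nM. Compound 2 therefore stands alone with a figure, while the other two rest at a limit, as recorded in the limit of > 350000 nM in this assay, at which 2 of the 3 values shown sit. Among the measured compounds shown here, no pair among the measured compounds differs in a single place, so there is no measured step to show what a change on the core of compound 2 does to this read-out.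

Compound 4 `Nc1ccn([C@@H]2O[C@H](CO)[C@](O)(C3CC3)[C@H]2O)c(=O)n1` is not yet measured. It differs from compound 2 in one respect: cyclopropyl in place of ethyl on a saturated ring carbon. For the measured compounds named here, with no measured step to lean on, the expectation for this change is no movement beyond the usual scatter, which would mean a 1.1-fold higher number from compound 2 to compound 4 (0.05 log units; within the scatter). Because compound 2 gives 269000 nM, compound 4 is estimated at about 300000 nM, within a range from 100000 nM to 1000000 nM.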

Compound 4, half-maximal inhibitory concentration: > 350000 nM
Compound 4 was reported as a limit; the forecaster's own chance of this, stated with the estimate: 50%; at least 1.1-fold (0.06 log units) between middle value and limit.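

Among these compounds, this is the first step read at this position: in this assay, cyclopropyl in place of ethyl on a saturated ring carbon, next to the ring atom that bears a hydroxymethyl group, gives an at least 1.3-fold higher number from compound 2 to compound 4 (0.11 log units; that floor lies within the scatter). Among the compounds shown here, that step is only a floor, and since the floor lies within the scatter, it does not establish that the ring costs anything; it shows only that the added three-membered ring does not bring the read-out down to a number lower than that of compound 2. Compound 4 yields a limit and not a number, so compound 2 remains the only compound with a figure, and the new result joins the others at the ceiling of the read-out: the limit of > 350000 nM in this assay, at which 3 of the 4 values shown sit.

Going by these compounds, how far the true value of compound 4 lies from that of compound 2 stays unknown, so the size of this change cannot be given. On these data alone, whether a methyl, a longer chain such as butyl, or an amine on the same ring carbon would give a lower number than compound 2 also stays open.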